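Trifluoromethyl in Place of Fluoro on the Phenyl Ring

The source may report more compounds than this note shows. Statements on the series, on what has been measured and on what is new or still open speak of the compounds shown alone.

Compound 3 `COc1cc2c(Oc3ccc(NC(=O)c4cc(-c5ccc(F)cc5)ccn4)cc3F)ccnc2cc1OCCCN1CCN(C)CC1` gives 510 nM in a functional assay on MKN-45 cells (Homo sapiens) for cytotoxicity, read by MTT assay, with a stated time of 72 h (on this read-out lower numbers stand for stronger inhibition and higher numbers for weaker inhibition), the second highest of three numbers. Compound 1 `COc1cc2c(Oc3ccc(NC(=O)c4cc(-c5ccccc5)ccn4)cc3F)ccnc2cc1OCCCN1CCN(C)CC1` gives 150 nM, and the step of a 3.4-fold higher number from compound 1 to compound 3 (0.53 log units; beyond the scatter) lies beyond the scatter. Among the compounds with values here, compound 2 `COc1cc2c(Oc3ccc(NC(=O)c4cc(-c5ccc(C(F)(F)F)cc5)ccn4)cc3F)ccnc2cc1OCCCN1CCCCC1` gives 870 nM; its gap to compound 3 lies within the scatter, but compound 2 also carries a different chain, so no single step joins it to compound 3. Compound 4 `COc1cc2c(Oc3ccc(NC(=O)c4cc(-c5ccc(C(F)(F)F)cc5)ccn4)cc3F)ccnc2cc1OCCCN1CCN(C)CC1` differs from compound 3 by trifluoromethyl in place of fluoro on an aromatic carbon. Within the data shown here, the only measured step that bears on this change is a modest one, a 3.4-fold higher number from compound 1 to compound 3 (0.53 log units; beyond the scatter), so for compound 4 a modest rise or none beyond the scatter is expected, a 1.6-fold higher number from compound 3 to compound 4 (0.20 log units; within the scatter). The estimate for compound 4 is 800 nM, ranging from 300 nM to 2500 nM.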

Compound 4, half-maximal inhibitory concentration: 330 nM
Beside the measured number, compound 4's estimate is 2.4-fold (0.38 log units) above it; the range from low to high includes it.
By their numbers in this assay, from the lowest: compound 1; then compounds 4, 3 and 2 (each within the scatter of the next, the first and the last beyond it).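

In this assay, trifluoromethyl and fluoro on this aromatic carbon, para to a large group, cannot be told apart, with a 1.5-fold lower number from compound 3 to compound 4 (0.19 log units; within the scatter) as the step, and hydrogen stays apart from trifluoromethyl, with a 2.2-fold higher number from compound 1 to compound 4 (0.34 log units; beyond the scatter) as the step. The chain end also counts on this scaffold, since 4-methylpiperazin-1-yl in place of piperidin-1-yl gives a 2.6-fold lower number from compound 2 to compound 4 (0.42 log units; beyond the scatter) as a step of its own. No evidence is available to explain these numbers.

Going by these compounds, whether a methoxy group, a nitrile or an amine on that carbon would stand with compound 1 or with compound 4 stays open. So does the effect of a morpholine at the chain end.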